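The source may report more compounds than this note shows. Statements on the series, on what has been measured and on what is new or still open speak of the compounds shown alone.

Compound 1 `Nc1nc(=O)ccn1COCCO` gives in a functional assay on L1210 cells (Mus musculus) for inhibition (on this read-out lower numbers stand for stronger inhibition and higher numbers for weaker inhibition), only > 500 ug/mL, which is a limit of the assay and not a number. That limit is restated as the limit of > 500 ug/mL in this assay, at which 1 of the 2 values shown sits, for compound 1. Among the measured compounds shown here, compound 2 `Cc1nc2c(O)nc(N)nc2n1COCCO` gives 323 ug/mL in this assay, the single full number so far. Compound 3 `Nc1nc(O)c2nc(N3CCCCC3)n(COCCO)c2n1` differs from compound 2 by piperidin-1-yl in place of methyl on an aromatic carbon. For the measured compounds named here, no measured pair shows the size of such a step, so the expected step of a 1.6-fold lower number from compound 2 to compound 3 (0.21 log units; within the scatter) is kept modest, toward stronger inhibition but not clearly beyond the usual scatter. Compound 3 is therefore estimated at 200 ug/mL, within 60 ug/mL to 500 ug/mL.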

Compound 3, concentration for 50% inhibition: > 500 ug/mL
Compound 3: a limit, no number (the forecaster's own chance of this, stated with the estimate: 35%); at least 2.5-fold (0.39 log units) between middle value and limit.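

In this assay compound 3 gives > 500 ug/mL, a limit and not a number. Piperidin-1-yl in place of methyl on this aromatic carbon brings no stronger inhibition, and the step reads an at least 1.5-fold higher number from compound 2 to compound 3 (0.18 log units; that floor lies within the scatter). Compound 2 remains the only compound with a full number, and the series now rests mostly on a limit: the limit of > 500 ug/mL in this assay, at which 2 of the 3 values shown sit.

From the compounds shown here alone, the true size of this step stays open. Also open, going by these compounds, is whether ethyl or dimethylamino on this carbon would give a full number in this assay.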